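Adding an Isopropyl Group to Compound 1

A few compounds are considered here, and "the series" means these few. Any claim that something is new, unique, unknown or untested is made for them only; others in the source may bear on it.

Among the measured compounds shown here, compound 1 `COc1ccc(Oc2ccccc2-c2ccsc2S(=O)(=O)NCCNC(=S)Nc2cc(C(F)(F)F)cc(C(F)(F)F)c2)cc1OC` is the only compound in this small set with a true number in an ADME assay on HEK-293T cells (Homo sapiens) for cytotoxicity, read by CCK-8 assay, with a stated time of 48 h; a lower number here means a stronger inhibitor, a higher number a weaker inhibitor: compound 1 gives 6800 nM. Compound 2 `O=[N+]([O-])c1ccc(NC(=S)NCCNS(=O)(=O)c2ccc(-c3ccccc3OCc3cccc(O)c3)s2)cc1` reports only a limit of this assay, at > 20000 nM. Compound 3 `O=C(NCCNS(=O)(=O)c1cc(-c2ccccc2Oc2ccc(O)c(O)c2)cs1)Nc1cc(Cl)cc(Cl)c1` also reports only a limit, at > 20000 nM. These two compounds differ from compound 1 in several places, so neither offers a clean comparison.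

Compound 4 `COc1ccc(Oc2ccc(C(C)C)cc2-c2ccsc2S(=O)(=O)NCCNC(=S)Nc2cc(C(F)(F)F)cc(C(F)(F)F)c2)cc1OC` departs from compound 1 in one place: isopropyl in place of hydrogen on an aromatic carbon. This is isopropyl in place of hydrogen on an aromatic carbon, para to a 3,4-dimethoxyphenoxy group. For the measured compounds named here, no measured pair here shows what such a change does, so the expectation stays modest and rests on compound 1 at 6800 nM: no shift beyond the usual scatter in this assay, with a slight lean towards a lower number. The estimated step is a 1.2-fold lower number from compound 1 to compound 4 (0.09 log units; within the scatter). Compound 4 is expected at 5500 nM, within an estimated range of 2200 nM to 15000 nM.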

Compound 4, half-maximal inhibitory concentration: 10200 nM
For compound 4 the middle estimate is 1.9-fold (0.27 log units) below the measured one, and the stated range covers the measured number.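

In this assay, isopropyl in place of hydrogen on an aromatic carbon, para to a 3,4-dimethoxyphenoxy group, gives a 1.5-fold higher number from compound 1 to compound 4 (0.18 log units; within the scatter). Among the compounds shown here, this is the first comparison here between compounds that differ in one place, and it shows that this position takes a group of three carbons without a shift beyond the scatter. Compound 2 and compound 3 each give a limit rather than a number, and neither can be set against this step: the limit of > 20000 nM in this assay, at which 2 of the 4 values shown sit.

The compounds shown leave open whether an amine, a carboxylic acid or a longer chain at this position would also stay within the scatter of compound 1. They also leave open whether isopropyl would have the same outcome at any other position on the core of compound 1.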